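The compounds below may be only part of what the source reports. "The series", "measured", "known", "first", "only" and "open" are said of these compounds alone.

Three members of the series differ only in the substituent on the phenyl attached to the aromatic nitrogen of the shared core. Compound 1 `CCNC(=O)c1cc(Oc2ccc(NC(=O)c3cc4cccnc4n(-c4ccc(F)cc4)c3=O)cc2)ccn1` gives 190 nM in a functional assay on HT-29 cells (Homo sapiens) for antiproliferative activity, read by MTT assay, with a stated time of 72 h; on this read-out higher numbers stand for weaker inhibition and lower numbers for stronger inhibition. Compound 2 `CCNC(=O)c1cc(Oc2ccc(NC(=O)c3cc4cccnc4n(-c4ccc(Br)cc4)c3=O)cc2)ccn1` gives 1160 nM in this assay, and compound 3 `CCNC(=O)c1cc(Oc2ccc(NC(=O)c3cc4cccnc4n(-c4ccc(OC)cc4)c3=O)cc2)ccn1` gives 3350 nM in this assay. Compound 3 thus stands highest of the three numbers: the step of an 18-fold higher number from compound 1 to compound 3 (1.25 log units; beyond the scatter) is the largest in the set, and a 2.9-fold higher number from compound 2 to compound 3 (0.46 log units; beyond the scatter) is also beyond the scatter, with a 6.1-fold higher number from compound 1 to compound 2 (0.79 log units; beyond the scatter) in between.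

Compound 4 `CCNC(=O)c1cc(Oc2ccc(NC(=O)c3cc4cccnc4n(-c4ccc(C(F)(F)F)cc4Cl)c3=O)cc2)ccn1` is the next step from compound 3: 2-chloro-4-(trifluoromethyl)phenyl in place of 4-methoxyphenyl on an aromatic nitrogen. The three measured steps all bear on this position, and both halogen-bearing compounds, compound 1 and compound 2, sit below compound 3 in this assay. Within the data shown here, no compound in the set carries a trifluoromethyl or a second substituent on that phenyl, so the size of the move is uncertain, but the direction is expected to follow compound 1 and compound 2. The step from compound 3 to compound 4 is therefore expected to be a 5.6-fold lower number from compound 3 to compound 4 (0.75 log units; beyond the scatter), and compound 4 is estimated at 600 nM in this assay, within a range of 150 nM to 2500 nM.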

Compound 4, half-maximal inhibitory concentration: 4770 nM
The estimate for compound 4 lay 8.0-fold (0.90 log units) below the measured number; the measured number lies above the stated range.
By their numbers in this assay, from the lowest: compound 1; then compound 2; then compounds 3 and 4 (each within the scatter of the next).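

In this assay the step of a 1.4-fold higher number from compound 3 to compound 4 (0.15 log units; within the scatter) places 2-chloro-4-(trifluoromethyl)phenyl level with 4-methoxyphenyl, so halogen on this phenyl does not by itself go with the lower numbers of compound 1 and compound 2. Compound 4 carries halogen too, yet a 4.1-fold higher number from compound 2 to compound 4 (0.61 log units; beyond the scatter) and a 25-fold higher number from compound 1 to compound 4 (1.40 log units; beyond the scatter) set it clearly apart from both, leaving 4-fluorophenyl with the lowest number at this position. Nothing available here gives a measured reason for these differences.

The compounds shown leave open whether the chloro or the trifluoromethyl part decides the number of compound 4, as the two appear only together. They also leave open where an unsubstituted phenyl, or a phenyl carrying an amine or a carboxylic acid, would stand.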